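Amide variations on a stilbene scaffold: toward an octyl amide

The source may hold more compounds than are shown below. What is called first, only, known or untested is meant among the compounds shown, and "the series" means these compounds.

Three compounds have been tested in a functional assay on MCF7 cells (Homo sapiens) for inhibition, read by MTT assay, with a stated time of 48 h; a lower number here means a stronger inhibitor, a higher number a weaker inhibitor:

Compound 1, `COc1ccc(/C=C/c2cc(OC)cc(OC)c2/C=C/C(=O)Nc2cc(OC)c(OC)c(OC)c2)cc1`, gives 7010 nM.
Compound 2, `COc1ccc(/C=C/c2cc(OC)cc(OC)c2/C=C/C(=O)N2CCN(C)CC2)cc1`, gives 2290 nM.
Compound 3, `COc1ccc(/C=C/c2cc(OC)cc(OC)c2/C=C/C(=O)N2CCCCC2C)cc1`, gives 4350 nM.

All three share the same core and differ only in the group attached to the carbonyl carbon. Compound 2 has the lowest number of the three: its nearest neighbour is compound 3, reached by a 1.9-fold higher number from compound 2 to compound 3 (0.28 log units; within the scatter), while compound 1 is further away, beyond the scatter. The unmeasured compound 4, `CCCCCCCCNC(=O)/C=C/c1c(/C=C/c2ccc(OC)cc2)cc(OC)cc1OC`, is obtained from compound 2 by a change at the same position: octylamino in place of 4-methylpiperazin-1-yl on a carbonyl carbon. Within the data shown here, the one measured step at this position, a 1.9-fold higher number from compound 2 to compound 3 (0.28 log units; within the scatter), swapped one ring for another and stayed within the scatter. Among the measured compounds shown here, no measured step introduces an open chain or a hydrogen-bond donor here, so that part of the change is untested. With only a within-scatter precedent, no large shift is expected in this assay, though the wide spread of the three measured amides leaves room for some drift upward. Compound 4 is therefore estimated at 3800 nM, with a range of 1400 nM to 11000 nM, which means an expected step of a 1.7-fold higher number from compound 2 to compound 4 (0.22 log units; within the scatter).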

Compound 4, half-maximal inhibitory concentration: 4280 nM
Estimate against measurement, compound 4: 1.1-fold (0.05 log units) below; the range from low to high includes it.
By their numbers in this assay, from the lowest: compounds 2, 4, 3 and 1 (each within the scatter of the next, the first and the last beyond it).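

In this assay, replacing the 4-methylpiperazin-1-yl ring with an open octylamino chain, which brings an amide hydrogen to this position, gives a step that stays within the scatter (a 1.9-fold higher number from compound 2 to compound 4 (0.27 log units; within the scatter)). Compound 4 also lies within the scatter of the other two amides (a 1.0-fold lower number from compound 3 to compound 4 (0.01 log units; within the scatter); a 1.6-fold lower number from compound 1 to compound 4 (0.21 log units; within the scatter)), even though compound 1 and compound 2 lie beyond the scatter of each other, so neither losing the ring nor adding the amide hydrogen produces a clear shift here. No measurement is available that could explain these numbers.

A methyl(octyl)amino group would keep the chain but lack the amide hydrogen, separating these two parts of the change. Also open, going by these compounds, is how a shorter butylamino chain, or an octyl chain ending in a carboxylic acid or an amine, would read in this assay.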